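Removing the Aryl Group from an Inactive Aniline

The source may report more compounds than this note shows. Statements on the series, on what has been measured and on what is new or still open speak of the compounds shown alone.

Compound 1, `C=C(Br)C(=O)Nc1ccc(/C=C2\SC(=O)N(Cc3ccc(C)cc3)C2=O)cc1`, gives 8900 nM in a functional assay on HeLa cells (Homo sapiens) for cytotoxicity, read by cell counting, with a stated time of 4 days; a lower number here means a stronger inhibitor, a higher number a weaker inhibitor.
Compound 2, `C=C(Br)C(=O)Nc1ccc(/C=C2\SC(=O)N(C)C2=O)cc1`, gives 870 nM in this assay.
Compound 3, `Cc1ccc(CN2C(=O)S/C(=C\c3ccc(N)cc3)C2=O)cc1`, is reported in this assay only as a limit of the assay, > 250000 nM.

Two changes are measured here. The first is hydrogen in place of 4-methylphenyl on a saturated chain carbon bound to an amide-type nitrogen in a ring. It produced a 10-fold lower number from compound 1 to compound 2 (1.01 log units; beyond the scatter), a clear gain in potency. The second is hydrogen in place of (1-bromoethenyl)carbonyl on a nitrogen on an aromatic ring. That change produced an at least 28-fold higher number from compound 1 to compound 3 (1.44 log units; beyond the scatter), so much that compound 3 reaches the point where the assay reports only a limit, as shown by the limit of > 250000 nM in this assay, at which 1 of the 3 values shown sits.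

Compound 4, `CN1C(=O)S/C(=C\c2ccc(N)cc2)C1=O`, has not yet been measured. It relates to compound 3 exactly as compound 2 relates to compound 1: the difference is hydrogen in place of 4-methylphenyl on a saturated chain carbon bound to an amide-type nitrogen in a ring. The place is described in the same words, so this is the same change. Compound 4 keeps the core of compound 3, lacking the (1-bromoethenyl)carbonyl group that compounds 1 and 2 carry.

If the change behaved as in the measured pair, compound 4 would be expected to be somewhat more potent than compound 3, with an estimated step of an at least 1.6-fold lower number from compound 3 to compound 4 (0.22 log units; that floor lies within the scatter). Yet the starting point is itself only a limit, so the gain may not bring compound 4 into the measurable range. Compound 4 is therefore estimated at 150000 nM in this assay, between 30000 nM and 600000 nM, with a fair chance that the assay again reports only a limit.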

Compound 4, half-maximal inhibitory concentration: 97000 nM
The estimate for compound 4 lay 1.5-fold (0.19 log units) above the measured number; the measured number falls inside the stated range.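

The measured value of compound 4 completes a square of four compounds, in which each change can be read on two cores. In this assay, hydrogen in place of 4-methylphenyl again gives a gain in potency, an at least 2.5-fold lower number from compound 3 to compound 4 (0.41 log units; beyond the scatter), and loss of the (1-bromoethenyl)carbonyl group again gives a large loss, a 110-fold higher number from compound 2 to compound 4 (2.05 log units; beyond the scatter). So the first change lowers the number on the core with the (1-bromoethenyl)carbonyl group and on the core with the free aniline nitrogen, which shows that its direction carries over, though not that its size does: the same change on two cores in this assay, a 10-fold lower number (1.01 log units; beyond the scatter) from compound 1 to compound 2 and an at least 2.5-fold lower number (0.41 log units; beyond the scatter) from compound 3 to compound 4; the limit leaves it open whether they differ. The second change likewise keeps its direction on the two cores, but its size cannot be pinned down either: the same change on two cores in this assay, an at least 28-fold higher number (1.44 log units; beyond the scatter) from compound 1 to compound 3 and a 110-fold higher number (2.05 log units; beyond the scatter) from compound 2 to compound 4; the limit leaves it open whether they differ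

The compounds shown cover only 4-methylphenyl and hydrogen on the saturated chain carbon bound to the amide-type nitrogen in the ring, so it remains open whether a longer chain or a carboxylic acid there would follow the same direction. They also leave open how much of the activity depends on the bromine, since a plain acetyl group on the aniline nitrogen, or a propenoyl group without bromine, is not among them.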